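The source may hold more compounds than are shown below. What is called first, only, known or untested is meant among the compounds shown, and "the series" means these compounds.

Measured compounds, read in an assay on HEK293 cells for activation of Kir3.1/Kir3.2 (Homo sapiens), read by thallium flux; on this read-out lower numbers stand for an effect already at smaller amounts and higher numbers for an effect only at larger amounts of compound:

compound 1 `Cc1cc(NC(=O)Cn2nnc(-c3ccccc3)n2)n(C2CCCCC2)n1` – 96 nM
compound 2 `Cc1cc(NC(=O)Cn2nnc(-c3cccc(Cl)c3)n2)n(C2CCCCC2)n1` – 300 nM
compound 3 `Cc1cc(NC(=O)Cn2nnc(-c3ccc(Cl)c(Cl)c3)n2)n(C2CCCCC2)n1` – 1220 nM

Compound 3 stands highest of the three in this assay; its nearest neighbour is compound 2, and compound 1 lies furthest from it. The two single-change steps within the set both run upward: a 3.1-fold higher number from compound 1 to compound 2 (0.49 log units; beyond the scatter) and a 4.1-fold higher number from compound 2 to compound 3 (0.61 log units; beyond the scatter); taken together they give a 13-fold higher number from compound 1 to compound 3 (1.10 log units; beyond the scatter).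

Compound 4 `Cc1cc(NC(=O)Cn2nnc(-c3cc(Cl)cc(Cl)c3)n2)n(C2CCCCC2)n1` has not been measured. It differs from compound 3 in one place: 3,5-dichlorophenyl in place of 3,4-dichlorophenyl on an aromatic carbon. The same atoms are present in both, joined differently. Within the data shown here, no measured pair shows this rearrangement of two chloro groups on the phenyl ring, so the steps above bear on it only indirectly. What they show is that each chloro added to the phenyl ring of this series raised the number in this assay by a modest step, and that compound 3, with two chloro groups, sits well above compound 1 and compound 2. Compound 4 keeps two chloro groups, so no step beyond the scatter is expected from compound 3 to compound 4 in this assay, with the direction uncertain.

For compound 4 the expected value is 1000 nM, with a range from 300 nM to 3500 nM; this corresponds to an estimated step of a 1.2-fold lower number from compound 3 to compound 4 (0.09 log units; within the scatter).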

Compound 4, half-maximal effective concentration: 980 nM
Beside the measured number, compound 4's estimate is 1.0-fold (0.01 log units) above it, and the stated range covers the measured number.
By their numbers in this assay, from the lowest: compound 1; then compound 2; then compounds 4 and 3 (each within the scatter of the next).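

In this assay, among these compounds, 3,5-dichlorophenyl in place of 3,4-dichlorophenyl gives a 1.2-fold lower number from compound 3 to compound 4 (0.10 log units; within the scatter), so on this aromatic carbon of the five-membered ring the two chloro arrangements cannot be told apart, a comparison the earlier compounds, which held only one dichloro pattern, could not offer. The second chloro also raises the number when it enters at a different place on the phenyl ring: a 3.3-fold higher number from compound 2 to compound 4 (0.51 log units; beyond the scatter) is a modest step like a 4.1-fold higher number from compound 2 to compound 3 (0.61 log units; beyond the scatter), and the whole change gives a 10-fold higher number from compound 1 to compound 4 (1.01 log units; beyond the scatter), large like a 13-fold higher number from compound 1 to compound 3 (1.10 log units; beyond the scatter), so among these four compounds the number follows the presence of the second chloro, with none going against this, rather than its exact place. No supporting data on the origin of this insensitivity to chloro placement are available here.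

The compounds shown leave open whether the rise belongs to chloro itself or to any group on the phenyl ring. On these data alone, a methoxy group, an amine or a carboxylic acid at these ring places would separate the two readings, and whether the unsubstituted phenyl of compound 1 remains the best choice also stays open.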